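A few compounds are considered here, and "the series" means these few. Any claim that something is new, unique, unknown or untested is made for them only; others in the source may bear on it.

Two compounds share the same core, a sulfonamide carrying a methoxy group and a chlorine. Compound 1 `COc1ccc(Cl)cc1S(=O)(=O)Nc1cncc(-c2ccccc2C)c1` bears a 2-methylphenyl group on an aromatic carbon; in an assay on isolated protein for inhibition of alkaline phosphatase, tissue-nonspecific isozyme (Homo sapiens) (a lower number here means a stronger inhibitor, a higher number a weaker inhibitor), compound 1 gives 178 nM. Compound 2 `COc1ccc(Cl)cc1S(=O)(=O)Nc1cncc(C(=O)O)c1` carries a carboxy group in that place instead, and in this assay compound 2 gives 134 nM. Within the data shown here, the only step measured so far, a 1.3-fold lower number from compound 1 to compound 2 (0.12 log units; within the scatter), lies within the scatter, so compound 2 stands beside compound 1 rather than apart from it.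

Compound 3 `COC(=O)c1cncc(NS(=O)(=O)c2cc(Cl)ccc2OC)c1` differs from compound 2 by methyl in place of hydrogen on an oxygen next to a carbonyl group. Among the measured compounds shown here, no measured step bears on this change: the one step in hand exchanges a whole ring for the carboxy group and says nothing about capping its oxygen with a methyl. The expectation for compound 3 in this assay therefore rests on compound 2 alone, with no firm direction. The estimate for compound 3 is 250 nM, ranging from 80 nM to 800 nM. The expected step from compound 2 to compound 3 is a 1.9-fold higher number from compound 2 to compound 3 (0.27 log units; within the scatter), a small move that may well stay within the scatter.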

Compound 3, half-maximal inhibitory concentration: 65 nM
Compound 3: middle estimate off by 3.8-fold (0.59 log units), on the high side, and the stated range ends above it.
By their numbers in this assay, from the lowest: compound 3; then compounds 2 and 1 (each within the scatter of the next).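

Placing a methyl on the oxygen of the carboxy group gives a 2.1-fold lower number from compound 2 to compound 3 (0.31 log units; beyond the scatter) in this assay. Among these compounds, this modest step is the first to lie beyond the scatter, and it shows that the numbers at this position can separate on a change as small as hydroxy to methoxy, which the exchange of 2-methylphenyl for carboxy did not show. Methoxycarbonyl also separates from the 2-methylphenyl group, with a 2.7-fold lower number from compound 1 to compound 3 (0.44 log units; beyond the scatter), so compound 3 has the lowest number of the three, and its steps to both other compounds lie beyond the scatter. No measurement here accounts for the difference that the methyl makes.

The compounds shown leave open whether a longer chain on that oxygen, such as ethyl or isopropyl, would continue this downward step or reverse it. They also leave open how an amide or a nitrile in place of methoxycarbonyl would read in this assay, and so whether the step depends on the capped oxygen or on some other part of the group.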